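Swapping Dichlorophenyl for Fluorophenyl on the Dimethoxy Core

The compounds below may be only part of what the source reports. "The series", "measured", "known", "first", "only" and "open" are said of these compounds alone.

Measured compounds:
compound 1 `O=S(=O)(/C=C/c1ccc(F)cc1)Cc1ccc(Nc2ncnc3ccccc23)cc1`: 100000 nM
compound 2 `O=S(=O)(/C=C/c1ccc(Cl)cc1Cl)Cc1ccc(Nc2ncnc3ccccc23)cc1`: 14000 nM
compound 3 `COc1cc2ncnc(Nc3ccc(CS(=O)(=O)/C=C/c4ccc(Cl)cc4Cl)cc3)c2cc1OC`: 2000 nM

Of the compounds shown here, three have been tested in a functional assay on SW-620 cells (Homo sapiens); a higher number here means a weaker inhibitor of growth, a lower number a stronger inhibitor of growth. Compound 3 gives the lowest number of the three, with compound 2 standing nearest and compound 1 furthest from it. Compound 2 and compound 3 share the anilino-quinazoline arrangement and the same side chain but differ in the core; the difference between the two cores is not broken down here.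

Within the pair that shares a core, one change is counted: 4-fluorophenyl in place of 2,4-dichlorophenyl on a double-bonded chain carbon bound to a double-bonded chain carbon. It gives a 7.1-fold higher number from compound 2 to compound 1 (0.85 log units; beyond the scatter), a step that lies beyond the scatter and goes toward weaker growth inhibition.

Compound 4 `COc1cc2ncnc(Nc3ccc(CS(=O)(=O)/C=C/c4ccc(F)cc4)cc3)c2cc1OC` has not yet been measured. It differs from compound 3 by 4-fluorophenyl in place of 2,4-dichlorophenyl on a double-bonded chain carbon bound to a double-bonded chain carbon. The two changes are the same, word for word, down to the place where they sit; only the core that carries them differs.

The expectation therefore rests on a single precedent. Because compound 2 to compound 1 gave a 7.1-fold higher number from compound 2 to compound 1 (0.85 log units; beyond the scatter), a step of about the same size and direction is expected from compound 3 to compound 4, namely a 7.0-fold higher number from compound 3 to compound 4 (0.85 log units; beyond the scatter). With only one earlier case, and on a different core, the range is kept wide. Compound 4 is estimated at 14000 nM in this assay, expected to fall between 5000 nM and 50000 nM.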

Compound 4, concentration for 50% growth inhibition: > 100000 nM
Compound 4 was reported as a limit; the forecaster's own chance of this, stated with the estimate: 10%; middle value at least 7.1-fold (0.85 log units) from the limit.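

In this assay compound 4 gives > 100000 nM, which is a limit of the assay and not a number. The change from 2,4-dichlorophenyl to 4-fluorophenyl gives an at least 50-fold higher number from compound 3 to compound 4 (1.69 log units; beyond the scatter), toward weaker growth inhibition as on the other core, so the direction carried over while the size did not: the same change on two cores in this assay, a 7.1-fold higher number (0.85 log units; beyond the scatter) from compound 2 to compound 1 and an at least 50-fold higher number (1.69 log units; beyond the scatter) from compound 3 to compound 4, at least 7.0-fold (0.84 log units) apart, beyond the scatter of two such steps The gap between the two steps is therefore a minimum, and with a single pair on each core it shows neither how large the step truly is on this core nor how the change would behave on any further core: the limit of > 100000 nM in this assay, at which 1 of the 4 values shown sits.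

The compounds shown leave open whether the larger step belongs to the fluorine that enters or to the chlorines that leave, a question that a phenyl ring carrying one chlorine, or an unsubstituted phenyl, would help to separate on both cores. They also leave open which part of the core of compound 3 sets the two steps apart, and a core carrying a single methoxy group would bear on that.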